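A few compounds are considered here, and "the series" means these few. Any claim that something is new, unique, unknown or untested is made for them only; others in the source may bear on it.

Measured so far:
compound 1 `Cc1cc(Oc2ccc(/C=N/NC(=S)Nc3ccc(F)cc3)cc2)ccc1Cl` gives 6.07 in a physicochemical assay for lipophilicity, in phosphate buffer, measured as octanol-water partition, with a stated time of 24 h; a lower number here means a more polar compound, a higher number a more lipophilic compound;
compound 2 `O=[N+]([O-])c1ccc(Oc2ccc(/C=N/NC(=S)Nc3ccc(Br)cc3)cc2)cc1` gives 5.68;
compound 3 `Cc1ccc(Oc2ccc(/C=N/NC(=S)Nc3ccc(Br)cc3)cc2)cc1` gives 6.17.

Compound 3 stands highest of the three numbers, though compound 1 lies within the scatter of it and only compound 2 lies clearly lower. Compound 4 `Cc1cc(Oc2ccc(/C=N/NC(=S)Nc3ccc(Br)cc3)cc2)ccc1Cl` differs from compound 3 by 4-chloro-3-methylphenyl in place of 4-methylphenyl on an oxygen on an aromatic ring. Within the data shown here, no measured step covers this exact change. The one step shown, a number 0.49 log units higher from compound 2 to compound 3 (beyond the scatter), concerns a different position and a different group, so it bears on this only loosely. The same 4-chloro-3-methylphenoxy group as in compound 4 is carried by compound 1, which gives 6.07. Compound 4 is therefore expected to move a number 0.23 log units higher from compound 3 to compound 4 (within the scatter), a small rise at most. The estimate for compound 4 is 6.4, with a range from 6 to 6.8.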

Compound 4, partition coefficient: 7.89
Estimate against measurement, compound 4: 1.49 log units below, and the stated range ends below it.
By their numbers in this assay, from the lowest: compound 2; then compounds 1 and 3 (each within the scatter of the next); then compound 4.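

In this assay, 4-chloro-3-methylphenyl in place of 4-methylphenyl on the oxygen gives a number 1.72 log units higher from compound 3 to compound 4 (beyond the scatter), and in place of 4-nitrophenyl it gives a number 2.21 log units higher from compound 2 to compound 4 (beyond the scatter). That group does not settle the number alone, since bromo in place of fluoro on an aromatic carbon, with the group kept, gives a number 1.82 log units higher from compound 1 to compound 4 (beyond the scatter). Nothing measured here accounts for the size of these steps.

Going by these compounds, whether the bromo-for-fluoro step would hold with other groups on the oxygen remains open. So does what a 4-aminophenyl or 4-carboxyphenyl group there would give.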